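Lengthening the Aminoalkyl Chain from Compound 2 to Compound 4

The source may report more compounds than this note shows. Statements on the series, on what has been measured and on what is new or still open speak of the compounds shown alone.

Measured so far:
Compound 1, `O=C(NCc1ccc(F)cc1)c1nc(Br)c2cccnc2c1NCCCNc1c(C(=O)NCc2ccc(F)cc2)nc(Br)c2cccnc12`: in a functional assay on HCT-116 cells (Homo sapiens) for cytotoxicity, read by MTT assay, with a stated time of 72 h (a higher number here means a weaker inhibitor, a lower number a stronger inhibitor), compound 1 gives > 20000 nM, which is a limit of the assay rather than a number.
Compound 2, `NCCNc1c(C(=O)NCc2ccc(F)cc2)nc(Br)c2cccnc12`: in this assay compound 2 gives > 20000 nM, again a limit and not a number.
Compound 3, `CS(=O)(=O)NCCCCCCN(c1nc(C(=O)NCc2ccc(F)cc2)c(O)c2ncccc12)S(C)(=O)=O`: in this assay compound 3 gives 4000 nM.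

Compound 2 therefore stands at the top of what the assay can report; (the limit of > 20000 nM in this assay, at which 2 of the 3 values shown sit). Compound 3 is the only one of the three with a numerical value.

Compound 4, `NCCCNc1c(C(=O)NCc2ccc(F)cc2)nc(Br)c2cccnc12`, differs from compound 2 in one place: aminomethyl in place of amino on a saturated chain carbon, two bonds along the chain from a nitrogen on an aromatic ring. Within the data shown here, no pair of measured compounds differing in a single place is available, so the size of such a step has not been observed directly. Since compound 2 already sits at the limit and the change is a single chain carbon, the step that the limit leaves unreadable from compound 2 to compound 4 is expected to be none beyond the usual scatter. Compound 4 is expected to give about 25000 nM in this assay, between 8000 nM and 80000 nM, most likely reported once more as a limit.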

Compound 4, half-maximal inhibitory concentration: 18000 nM
Compound 4: the middle estimate sits 1.4-fold (0.14 log units) above what was measured; the range from low to high includes it.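

In this assay compound 4 gives 18000 nM with the (3-aminopropyl)amino chain, so this position now yields a number on the shared core, which the (2-aminoethyl)amino chain did not. Compound 2 gives > 20000 nM as a limit of the assay and not a number. The change to aminomethyl in place of amino therefore reads only as an at least 1.1-fold lower number from compound 2 to compound 4 (0.04 log units; that floor lies within the scatter) and its real size cannot be told because of that limit: the limit of > 20000 nM in this assay, at which 2 of the 4 values shown sit.

On these data alone, whether a 4-aminobutyl chain on the same core would lower the number further stays open, as does the effect of an acetyl group on the terminal amine. Compound 3 differs from compound 4 in more than one place, so it does not settle either question.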